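Moving a Methyl Around the Outer Phenyl Ring

The compounds below may be only part of what the source reports. "The series", "measured", "known", "first", "only" and "open" are said of these compounds alone.

Measured compounds and their values in a functional assay on A549 cells (Homo sapiens) for cytotoxicity, read by MTT assay, with a stated time of 72 h; on this read-out higher numbers stand for weaker inhibition and lower numbers for stronger inhibition:
compound 1, `Cc1ccc(-c2ccc(C(=O)Nc3ccc(Oc4ccnc5[nH]ccc45)cc3)nc2)cc1`: > 10000 nM (a limit of the assay, not a number)
compound 2, `CCc1ccc(-c2ccc(C(=O)Nc3ccc(Oc4ccnc5[nH]ccc45)cc3)nc2)cc1`: > 10000 nM (a limit of the assay, not a number)
compound 3, `Cc1ccc(-c2ccnc(C(=O)Nc3ccc(Oc4ccnc5[nH]ccc45)cc3)c2)cc1`: > 10000 nM (a limit of the assay, not a number)

Compound 3 stands where every measured compound stands: at a limit, so no number for it is known. Among the compounds with values here, the same holds for compound 1 and compound 2, and the only step between compounds that differ in one place, a step that the two limits leave unreadable from compound 1 to compound 2, therefore cannot be read. The whole picture so far is summed up by the limit of > 10000 nM in this assay, at which 3 of the 3 values shown sit.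

Compound 4, `Cc1cccc(-c2ccnc(C(=O)Nc3ccc(Oc4ccnc5[nH]ccc45)cc3)c2)c1`, is not yet measured. It differs from compound 3 by 3-methylphenyl in place of 4-methylphenyl on an aromatic carbon. Within the data shown here, no measured step bears on this kind of change, and the one step that exists is unreadable, so nothing in the data points to a step in either direction in this assay; the expectation is simply that compound 4 again reaches no measurable number.

Accordingly, compound 4 is estimated at 20000 nM, with a range from 8000 nM to 60000 nM. That estimate amounts to an expected step that the limit leaves unreadable from compound 3 to compound 4, which is no change beyond the scatter.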

Compound 4, half-maximal inhibitory concentration: 7010 nM
Beside the measured number, compound 4's estimate is 2.9-fold (0.46 log units) above it; measured number outside the range, below it.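

Within the data shown here, compound 4 is the first compound here to give a real number in this assay, and it reaches that number with the same atoms as compound 3, joined differently: 3-methylphenyl in place of 4-methylphenyl. The comparison gives an at least 1.4-fold lower number from compound 3 to compound 4 (0.15 log units; that floor lies within the scatter); one end of it is a limit of the assay, so this size is only a floor, the true step may be larger, and the floor itself does not show a change beyond the scatter. Even so, moving a methyl around the outer ring now offers a measured value against which further changes can be read, a first for a set otherwise defined by this: the limit of > 10000 nM in this assay, at which 3 of the 4 values shown sit.

Among these compounds, still open is whether the same move of the methyl would also give a number on the core of compound 1, where the only readable values so far are limits. Also open, going by these compounds, is what would happen if the methyl of compound 4 were replaced by a chlorine atom, a methoxy group, an amine, a carboxylic acid or a longer chain such as propyl.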